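Isopropyl for pyridinylmethyl on the piperazine nitrogen: stability expected

The source may report more compounds than this note shows. Statements on the series, on what has been measured and on what is new or still open speak of the compounds shown alone.

Measured compounds:
compound 1 `CN(C[C@H]1Cc2c(cccc2N2CCN(Cc3ccccn3)CC2)CN1)[C@H]1CCCc2cccnc21` gives 4.2%
compound 2 `CCCN(C[C@H]1Cc2c(cccc2N2CCNCC2)CN1)[C@H]1CCCc2cccnc21` gives 100%
compound 3 `CCN1CCN(c2cccc3c2C[C@H](CN(C)[C@H]2CCCc4cccnc42)NC3)CC1` gives 0%

These values come from an ADME assay on microsomes from liver (Homo sapiens) for metabolic stability, read by LC-MS, with a stated time of 10 min; on this read-out higher numbers stand for a more stable compound and lower numbers for a less stable compound. Compound 1 stands second highest of the three; compound 3 sits close to it, within the scatter, while compound 2, which differs from compound 1 in two places, lies far above both. Compound 4 `CC(C)N1CCN(c2cccc3c2C[C@H](CN(C)[C@H]2CCCc4cccnc42)NC3)CC1` carries isopropyl in place of (pyridin-2-yl)methyl on an amine nitrogen in a ring. Within the data shown here, the one step that bears on this change is a number 4.2 percentage points lower from compound 1 to compound 3 (within the scatter), which stayed within the scatter when a small group replaced the (pyridin-2-yl)methyl at the same ring nitrogen. A similar outcome is therefore expected here: a number 3.8 percentage points higher from compound 1 to compound 4 (within the scatter), no shift beyond the scatter. Compound 4 is estimated at 8%, between 0% and 30%.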

Compound 4, percent of the compound remaining: 56.6%
Compound 4: middle estimate off by 48.6 percentage points, on the low side, outside the stated range (above it).
By their numbers in this assay, from the lowest: compounds 3 and 1 (each within the scatter of the next); then compound 4; then compound 2.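

In this assay the group on this ring nitrogen proves decisive: isopropyl in place of (pyridin-2-yl)methyl gives a number 52.4 percentage points higher from compound 1 to compound 4 (beyond the scatter) as a large step. A single added methyl on the chain carbon bound to that nitrogen also counts, with a number 56.6 percentage points higher from compound 3 to compound 4 (beyond the scatter) separating the ethyl group from the isopropyl group, so a small group at this position does not by itself settle the outcome. No available measurement explains these rises.

The compounds shown leave open whether cyclopropyl or tert-butyl on this nitrogen would match isopropyl.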